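The source may hold more compounds than are shown below. What is called first, only, known or untested is meant among the compounds shown, and "the series" means these compounds.

In a functional assay on CHO cells for agonist activity at Free fatty acid receptor 1 (Homo sapiens), read by a luciferase reporter (a higher number here means a larger maximal response, a lower number a smaller maximal response), compound 1 `O=C(O)COc1ccc(NCc2cccc(Oc3ccccc3)c2)cc1` gives 84%, compound 2 `O=C(O)[C@H]1C[C@@H]1c1ccc(NCc2cccc(Oc3ccccc3)c2)cc1` gives 88%; 72% (2 entries), and compound 3 `O=C(O)[C@@H]1C[C@H]1c1ccc(NCc2cccc(Oc3ccccc3)c2)cc1` gives 64%, the lowest of the two single numbers, with compound 1 standing higher; the step of a number 20 percentage points lower from compound 1 to compound 3 (beyond the scatter) lies beyond the scatter. Compound 2 and compound 3 are told apart only by configuration (the fact that compounds 2 and 3 differ only in the configuration as drawn), and the repeated entries of compound 2 the several entries of compound 2 in this assay, 88%; 72% (2 entries) show how far single readings can wander. Compound 4 `CNC(=O)CCc1ccc(NCc2cccc(Oc3ccccc3)c2)cc1` differs from compound 3 by 2-(methylcarbamoyl)ethyl in place of 2-carboxycyclopropyl on an aromatic carbon. Among the measured compounds shown here, no measured step exchanges the 2-carboxycyclopropyl for an uncharged chain, so the only comparable step, a number 20 percentage points lower from compound 1 to compound 3 (beyond the scatter), merely shows that changes at that place have lowered the maximal response modestly. A larger fall is expected for compound 4, a number 29 percentage points lower from compound 3 to compound 4 (beyond the scatter), giving an estimated 35% with a range of 5% to 70%.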

Compound 4, largest response reached (reported as percent of maximum), in percent of the reference or control that the assay uses: 67%
For compound 4 the middle estimate is 32 percentage points below the measured one; measured number inside the range.
By their numbers in this assay, from the lowest: compounds 3 and 4 (each within the scatter of the next); then compound 1.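

In this assay, the open 2-(methylcarbamoyl)ethyl chain in place of the 2-carboxycyclopropyl gives a number 3 percentage points higher from compound 3 to compound 4 (within the scatter). At this place, para to a large group, the three-membered ring and its two defined stereocentres can therefore be exchanged for this chain without a change in maximal response beyond the scatter. Measured against the carboxymethoxy group, the chain gives a number 17 percentage points lower from compound 1 to compound 4 (beyond the scatter), in the same direction as a number 20 percentage points lower from compound 1 to compound 3 (beyond the scatter).

As far as these compounds go, it remains open how a carboxylic acid on an open chain would read at this place. The same holds for an amine or a longer chain.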